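A few compounds are considered here, and "the series" means these few. Any claim that something is new, unique, unknown or untested is made for them only; others in the source may bear on it.

Compound 1 `C=C[C@]1(C)CC[C@@H](C(=C)CNC(C)(C)C)C[C@H]1C(=C)C` gives 25400 nM in a functional assay on HeLa cells (Homo sapiens) for antiproliferative activity, read by WST assay, with a stated time of 24 h; a lower number here means a stronger inhibitor, a higher number a weaker inhibitor.
Compound 2 `C=C[C@]1(C)CC[C@@H](C(=C)CNCCCC)C[C@H]1C(=C)C` gives 10800 nM in this assay.

Among the measured compounds shown here, compound 2 stands with the lowest of the two numbers measured so far; the only neighbour is compound 1, and the one measured step, a 2.4-fold lower number from compound 1 to compound 2 (0.37 log units; beyond the scatter), is modest. Compound 3 `C=C[C@]1(C)CC[C@@H](C(=C)Cn2ccnc2)C[C@H]1C(=C)C` differs from compound 2 in one place: 1H-imidazol-1-yl in place of butylamino on a saturated chain carbon bound to a double-bonded chain carbon. For the measured compounds named here, no measured step covers this kind of change. Going by the values given here, the single step from compound 1 to compound 2 only swaps one alkyl group for another on the amine nitrogen, whereas here the butylamino group gives way to a five-membered aromatic ring, so the measured step bears on it only loosely. With no closer guide, compound 3 is expected to land near compound 2, with a step of a 1.4-fold higher number from compound 2 to compound 3 (0.14 log units; within the scatter) that might or might not exceed the scatter. The estimate for compound 3 in this assay is therefore 15000 nM, within a range from 5000 nM to 50000 nM.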

Compound 3, half-maximal inhibitory concentration: 15700 nM
Beside the measured number, compound 3's estimate is 1.0-fold (0.02 log units) below it; the measured number falls inside the stated range.
By their numbers in this assay, from the lowest: compounds 2, 3 and 1 (each within the scatter of the next, the first and the last beyond it).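

The result shows that this place, a saturated chain carbon bound to a double-bonded chain carbon, can carry a five-membered aromatic ring as well as an open-chain amine: in this assay the ring gives (a 1.5-fold higher number from compound 2 to compound 3 (0.16 log units; within the scatter)) and also (a 1.6-fold lower number from compound 1 to compound 3 (0.21 log units; within the scatter)). Both steps stay within the scatter even though 1H-imidazol-1-yl has no hydrogen-bond donor where butylamino has one, so at this level of activity the hydrogen on the amine nitrogen is not required. Nothing available here explains this result.

The compounds shown leave open whether another ring, such as phenyl or a triazole, would read the same at this place. They also leave open whether a group without nitrogen, such as a hydroxyl or a carboxylic acid, would hold the number or shift it well beyond the scatter.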